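Hydroxypropyl to isobutyl on the shared core

A few compounds are considered here, and "the series" means these few. Any claim that something is new, unique, unknown or untested is made for them only; others in the source may bear on it.

Among the compounds with values here, in a functional assay on HL-60 cells (Homo sapiens) for antiproliferative activity, read by MTT assay (on this read-out lower numbers stand for stronger inhibition and higher numbers for weaker inhibition), compound 3 (`OCCC[C@@H]1O[C@H](COCc2ccccc2)[C@@H](OCc2ccccc2)[C@H](OCc2ccccc2)[C@H]1O`) gives 19300 nM as the only number so far. Compound 1 (`CC(C)C[C@H]1O[C@H](COCc2ccccc2)[C@@H](OCc2ccccc2)[C@H](OCc2ccccc2)[C@@H]1O`) is recorded as "not active" (no number reported) with no figure, and compound 2 (`CC(C)C[C@@H]1O[C@H](COCc2ccccc2)[C@H](OCc2ccccc2)[C@H](OCc2ccccc2)[C@H]1O`) is recorded as "not active" (no number reported) in the same way. Going by the fact that compounds 1 and 2 differ only in the configuration as drawn, a difference in configuration alone left both without a number.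

Compound 4 (`CC(C)C[C@@H]1O[C@H](COCc2ccccc2)[C@@H](OCc2ccccc2)[C@H](OCc2ccccc2)[C@H]1O`) changes the chain of compound 3: isopropyl in place of 2-hydroxyethyl on a saturated chain carbon bound to a saturated ring carbon (isopropyl in place of 2-hydroxyethyl on a saturated chain carbon bound to a saturated ring carbon, or 3-hydroxypropyl to isobutyl when cut one bond further out).

Within the data shown here, no measured step isolates this change. The isobutyl chain is shared by compound 1 at "not active" (no number reported) and compound 2 at "not active" (no number reported), so a weakening in this assay is expected, and a result with no number is the likelier outcome. The expected size, should a number appear, is a 1.6-fold higher number from compound 3 to compound 4 (0.19 log units; within the scatter) (modest). For compound 4 the estimate is 30000 nM (expected range 12000 nM to 80000 nM).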

Compound 4, half-maximal inhibitory concentration: 8500 nM
Compound 4: the middle estimate sits 3.5-fold (0.55 log units) above what was measured; measured number outside the range, below it.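

Replacing 3-hydroxypropyl with isobutyl at this position on the shared core gives a 2.3-fold lower number from compound 3 to compound 4 (0.36 log units; beyond the scatter) in this assay, so 3-hydroxypropyl is not needed for a measurable value. The isobutyl chain alone therefore does not account for the missing number of compound 1, recorded as "not active" (no number reported), and configuration separates it from compound 4: the fact that compounds 1 and 4 differ only in the configuration as drawn. The same holds for compound 2, recorded as "not active" (no number reported): the fact that compounds 2 and 4 differ only in the configuration as drawn

The step changes both the branching and the terminal hydroxyl at once, and the compounds shown do not separate the two. On these data alone, a straight butyl chain or a 3-aminopropyl chain on the core of compound 4 would bear on that, and how 3-hydroxypropyl behaves in the configurations of compound 1 and compound 2 also stays open.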